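A Larger Alkyl Group Enters Compound 4

The compounds below may be only part of what the source reports. "The series", "measured", "known", "first", "only" and "open" are said of these compounds alone.

Compound 1 `NC(=S)Nc1ccccc1CO` and compound 2 `NC(=S)NCc1ccccc1` were both tested in a functional assay on B16 cells (Mus musculus) for inhibition, tested at 10 uM; on this read-out lower numbers stand for less inhibition and higher numbers for more inhibition at the one concentration tested (going by the name of the read-out). For compound 1 the result is only a limit of the assay, < 10%. For compound 2 the result is likewise a limit, < 10%. Among the measured compounds shown here, compound 3 `Cc1ccc(/C=N/NC(N)=S)cc1` gives 64% in this assay, the only number among the three results, since the other two sit at the limit of < 10% in this assay, at which 2 of the 3 values shown sit.

Compound 4 `CC(C)(C)c1ccc(/C=N/NC(N)=S)cc1` differs from compound 3 in one place: tert-butyl in place of methyl on an aromatic carbon. For the measured compounds named here, no measured pair shows this change, so the step is judged from compound 3 alone. Compound 4 is expected to give 65% in this assay, within a range of 45% to 85%. The expected step of a number 1 percentage points higher from compound 3 to compound 4 (within the scatter) is estimated to stay within the usual scatter.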

Compound 4, a percentage reported as inhibition, at one concentration (the size of the read-out at that concentration, not a potency): 100%
The estimate for compound 4 lay 35 percentage points below the measured number, and the stated range ends below it.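

The position on an aromatic carbon, para to a group of 6 heavy atoms, proves sensitive to the group it carries: in this assay tert-butyl in place of methyl gives a number 36 percentage points higher from compound 3 to compound 4 (beyond the scatter) and so takes the read-out well past what compound 3 reached. Among the compounds shown here, the earlier compounds offered no such single change, so this pair is the first view of this position. Nothing shown gives a reason for the rise.

The compounds shown leave open how an ethyl group, an isopropyl group, a methoxy group or an amine would fare at this position. Going by these compounds, because each read-out comes from one concentration, how far compound 4 outdoes compound 3 in potency also stays open.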